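Half-life notes: oxadiazole series, compound 3 pending

The compounds below may be only part of what the source reports. "The series", "measured", "known", "first", "only" and "open" are said of these compounds alone.

Measured so far:
compound 1 `NS(=O)(=O)c1cc(-c2nnc(Cn3cc(-c4ccccc4)nn3)o2)c(Cl)cc1SCc1ccccc1`: 0.21 h
compound 2 `COc1ccc(-c2cn(Cc3nnc(-c4cc(S(N)(=O)=O)c(SCc5ccccc5)cc4Cl)o3)nn2)cc1`: 0.215 h

In an ADME assay on microsomes from liver (Homo sapiens) for metabolic stability, read by LC-MS, using NADPH, tested at 5 uM (a lower number here means that the compound disappears faster, a higher number that the compound lasts longer), compound 1 gives 0.21 h, the lower of the two numbers, with compound 2 at 0.215 h; the step of a 1.0-fold higher number from compound 1 to compound 2 (0.01 log units; within the scatter) is within the scatter. Compound 3 `NS(=O)(=O)c1cc(-c2nnc(/C=C/c3ccc(Cl)cc3)o2)c(Cl)cc1SCc1ccccc1` differs from compound 1 by 2-(4-chlorophenyl)ethenyl in place of (4-phenyl-1H-1,2,3-triazol-1-yl)methyl on an aromatic carbon. Within the data shown here, no measured step touches this part of the molecule; the one step known, methoxy for hydrogen, changed nothing beyond the scatter. With nothing to point elsewhere, compound 3 is expected near compound 1, as a 1.1-fold lower number from compound 1 to compound 3 (0.02 log units; within the scatter), with a wide range: estimate 0.2 h, between 0.08 h and 0.5 h.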

Compound 3, half-life: 0.207 h
For compound 3 the middle estimate is 1.0-fold (0.01 log units) below the measured one; measured number inside the range.
By their numbers in this assay, from the lowest: compounds 3, 1 and 2 (each within the scatter of the next).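

In this assay, putting 2-(4-chlorophenyl)ethenyl in place of (4-phenyl-1H-1,2,3-triazol-1-yl)methyl gives a 1.0-fold lower number from compound 1 to compound 3 (0.01 log units; within the scatter) and so shows no difference beyond the scatter. The methoxy step left this group in place, whereas this step replaces it entirely, including the five-membered aromatic ring with 3 hetero atoms. Nothing available explains this result.

Still open, on these data alone, is whether an amine or a carboxylic acid at this position would give a step beyond the scatter. The core is shared by all three compounds, so its part in these numbers cannot be read.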